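The compounds below may be only part of what the source reports. "The series", "measured", "known", "first", "only" and "open" are said of these compounds alone.

Measured compounds in a physicochemical assay for solubility, read by LC-MS, with a stated time of 16 h, at pH 7; a lower number here means a less soluble compound, a higher number a more soluble compound:
- compound 1, `CCCC[S+]([O-])c1sc2nc(-c3nccn3C)nc(-c3ccccc3)c2c1N`, gives 71 ug/mL
- compound 2, `CCCC[S+]([O-])c1sc2nc(-c3nccs3)cc(-c3cnc(C)[nH]3)c2c1N`, gives 4.1 ug/mL
- compound 3, `CCCC[S+]([O-])c1sc2nc(-c3nccn3C)cc(-c3ccccc3)c2c1N`, gives 1.9 ug/mL

Among these three numbers in this assay compound 2 stands second highest. Its nearest neighbour is compound 3, whose value is lower by a margin beyond the usual scatter; the furthest is compound 1, whose value is higher by a margin well beyond the scatter. Among the measured compounds shown here, no single-point step between two measured compounds is available here, so the move to the next compound rests on the structures alone.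

Compound 4, `CCCC[S+]([O-])c1sc2nc(-c3nccs3)cc(-c3nccs3)c2c1N`, has not yet been measured in this assay. It differs from compound 2 in one place: 1,3-thiazol-2-yl in place of 2-methyl-1H-imidazol-5-yl on an aromatic carbon. The group that leaves carries a hydrogen-bond donor, the group that enters carries none, and the six-membered ring of compound 4 then bears two 1,3-thiazol-2-yl groups.

For the measured compounds named here, with no measured step of this kind to lean on, the expectation for compound 4 is a small downward step, a 1.6-fold lower number from compound 2 to compound 4 (0.21 log units; within the scatter), at about the edge of the scatter. The estimated solubility of compound 4 in this assay is 2.5 ug/mL, with a range from 0.7 ug/mL to 9 ug/mL.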

Compound 4, solubility: 0.3 ug/mL
Compound 4: the middle estimate sits 8.3-fold (0.92 log units) above what was measured, outside the stated range (below it).
By their numbers in this assay, from the lowest: compound 4; then compound 3; then compound 2; then compound 1.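

In this assay, among the compounds shown here, the group on the aromatic carbon opposite the ring nitrogen proves far from indifferent: 1,3-thiazol-2-yl in place of 2-methyl-1H-imidazol-5-yl goes with a 14-fold lower number from compound 2 to compound 4 (1.14 log units; beyond the scatter) and gives the first single-place comparison in this set. Both groups are five-membered aromatic rings with 2 hetero atoms and differ little in size, so even a swap between similar-looking rings can be a large step at this position. Nothing measured on these compounds accounts for the step.

The swap removes a hydrogen-bond donor and a methyl and brings in a sulfur all at once, and these compounds cannot separate those changes. On these data alone, whether an imidazolyl ring without its methyl, an amine or a carboxylic acid at this place would give a higher number than compound 2 stays open.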